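The compounds below may be only part of what the source reports. "The series", "measured", "known", "first", "only" and "open" are said of these compounds alone.

Measured so far in an ADME assay on a cell-free system (plasma, Rattus norvegicus) for protein binding; on this read-out higher numbers stand for a larger free fraction and lower numbers for a smaller free fraction:
- compound 1 `N#Cc1ccc(O[C@H]2CN(S(=O)(=O)c3ccc(C(F)(F)F)cc3)C[C@@]2(O)CO)cc1F` gives 0.033
- compound 2 `N#Cc1ccc(O[C@H]2CN(S(=O)(=O)c3ccc(Cl)cn3)C[C@@]2(O)CO)cc1F` gives 0.18
- compound 3 `N#Cc1ccc(O[C@H]2CN(S(=O)(=O)c3ccc(Cl)cc3)C[C@@]2(O)CO)cc1F` gives 0.035

Compound 3 lies within the scatter of compound 1 and well under compound 2, the step being a 5.1-fold lower number from compound 2 to compound 3 (0.71 log units; beyond the scatter). Compound 4 `N#Cc1ccc(O[C@H]2CN(S(=O)(=O)c3ccc(C(F)(F)F)nc3)C[C@@]2(O)CO)cc1F` has 6-(trifluoromethyl)pyridin-3-yl in place of 4-chlorophenyl on a sulfonyl sulfur as its change from compound 3. Going by the values given here, two measured steps bear on this. Chloro in place of trifluoromethyl on an aromatic carbon gave a 1.1-fold higher number from compound 1 to compound 3 (0.03 log units; within the scatter), which is within the scatter. 5-chloropyridin-2-yl in place of 4-(trifluoromethyl)phenyl on a sulfonyl sulfur gave a 5.5-fold higher number from compound 1 to compound 2 (0.74 log units; beyond the scatter), a clear rise. The pyridine group in compound 4 is a different one, so only part of that rise is expected, an estimated 2.6-fold higher number from compound 3 to compound 4 (0.41 log units; beyond the scatter) in this assay. Compound 4 is expected at about 0.09, with an estimated range from 0.045 to 0.18.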

Compound 4, unbound fraction: 0.147
Estimate against measurement, compound 4: 1.6-fold (0.21 log units) below, and the stated range covers the measured number.
By their numbers in this assay, from the lowest: compounds 1 and 3 (each within the scatter of the next); then compounds 4 and 2 (each within the scatter of the next).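

In this assay, the higher number no longer belongs to a single pyridine group on the sulfonyl sulfur. It appears with a second one, with a 4.2-fold higher number from compound 3 to compound 4 (0.62 log units; beyond the scatter) and a 4.5-fold higher number from compound 1 to compound 4 (0.65 log units; beyond the scatter). Exchanging one pyridine group for the other gives a 1.2-fold lower number from compound 2 to compound 4 (0.09 log units; within the scatter), so the chloro and trifluoromethyl pyridines cannot be told apart here, and nothing shown explains why both pyridine compounds stand above the two phenyl compounds.

Still open, as far as these compounds go, is whether a pyridine carrying a methoxy group, or a pyrimidine with a second ring nitrogen, would keep the number at this level.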